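This account rests on a few compounds, and the source may have more. Where it says the series, first, only, none or still open, it means among the compounds named here.

Measured in a functional assay on MGC-803 cells (Homo sapiens) for cytotoxicity, read by MTT assay, with a stated time of 72 h; a lower number here means a stronger inhibitor, a higher number a weaker inhibitor:

Compound 1 `CC(=O)c1ccc(NC(=O)CSC(=S)N[C@H]2CCOC2=O)cc1`: 99400 nM
Compound 2 `CCCCc1ccc(NC(=O)CSC(=S)N[C@H]2CCOC2=O)cc1`: 20500 nM

Of these two compounds, compound 1 has the higher number and is the weaker inhibitor. Going by the values given here, the only measured step is a 4.8-fold lower number from compound 1 to compound 2 (0.69 log units; beyond the scatter), a modest change that lies beyond the scatter.

Compound 3 `O=C(CSC(=S)N[C@H]1CCOC1=O)Nc1ccc(C(=O)/C=C/c2cccc(Cl)c2)cc1` has not yet been measured. It keeps the core of compound 1 and differs in one place: 2-(3-chlorophenyl)ethenyl in place of methyl on a carbonyl carbon. In words, this is 2-(3-chlorophenyl)ethenyl in place of methyl on a carbonyl carbon.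

Among the compounds with values here, no measured compound carries this new group, so the evidence is thin. Within the data shown here, the one step bearing on it replaced the whole acetyl group, the same group that is extended in compound 3. On that single precedent, a modest step towards a lower number is expected in this assay, perhaps somewhat larger than the measured one. The expected change is an 8.3-fold lower number from compound 1 to compound 3 (0.92 log units; beyond the scatter). For compound 3, the estimated value is 12000 nM, with an expected range from 2500 nM to 50000 nM.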

Compound 3, half-maximal inhibitory concentration: 15600 nM
Compound 3: the middle estimate sits 1.3-fold (0.11 log units) below what was measured; low and high end bracket the measured number.
By their numbers in this assay, from the lowest: compounds 3 and 2 (each within the scatter of the next); then compound 1.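

In this assay, keeping the carbonyl and placing 2-(3-chlorophenyl)ethenyl on it in place of methyl gives a 6.4-fold lower number from compound 1 to compound 3 (0.80 log units; beyond the scatter). The earlier step, a 4.8-fold lower number from compound 1 to compound 2 (0.69 log units; beyond the scatter), removed the whole acetyl group, so it could not show whether a lower number required losing the carbonyl; this result shows that it does not. The position on the carbonyl carbon also accepts a group of 9 heavy atoms, with a six-membered aromatic ring and a double bond outside aromatic rings, and the number still falls from the 99400 nM of compound 1, though nothing available explains this fall.

The compounds shown do not separate the contributions of the chlorine, the aromatic ring and the double bond, since all three enter together in compound 3. On these data alone, what a methoxy group or an amine in place of the chlorine would do remains open, as does the effect of a saturated two-carbon link in place of the ethenyl part.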